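The source may report more compounds than this note shows. Statements on the series, on what has been measured and on what is new or still open speak of the compounds shown alone.

Of the compounds shown here, two have been measured so far. Compound 1 `Nc1scc(CN2CCN(c3ccc(Cl)c(C(F)(F)F)c3)CC2)c1C(=O)c1ccc(Cl)cc1` gives -47% in a functional assay on CHO cells with adenosine receptor A1 (Homo sapiens) as the target, read by cAMP accumulation and immunoassay, with a stated time of 6 min, tested at 1 uM; on this read-out lower numbers stand for a stronger effect and higher numbers for a weaker effect at the one concentration tested. Compound 2 `Nc1scc(CN2CCN(c3ccncc3)CC2)c1C(=O)c1ccc(Cl)cc1` gives -8.3% in this assay, which is the higher of the two numbers, so that compound 2 stands as the weaker of the pair at this concentration. For the measured compounds named here, the one step connecting them, a number 38.7 percentage points higher from compound 1 to compound 2 (beyond the scatter), shows that exchanging the 4-chloro-3-(trifluoromethyl)phenyl group for pyridin-4-yl on the amine nitrogen in the ring weakened the effect considerably.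

Compound 3 `Nc1scc(CN2CCN(c3ccc(F)cc3F)CC2)c1C(=O)c1ccc(Cl)cc1` has not yet been measured in this assay. It differs from compound 2 as follows: 2,4-difluorophenyl in place of pyridin-4-yl on an amine nitrogen in a ring. The entering group is, like the group in compound 1, a six-membered aromatic ring of carbon only carrying halogens, while the departing group is the pyridin-4-yl that accompanied the weakening seen in a number 38.7 percentage points higher from compound 1 to compound 2 (beyond the scatter). That step is the only one that bears on this change, and it was large. The effect of compound 3 is therefore expected to be stronger than that of compound 2, by an estimated a number 21.7 percentage points lower from compound 2 to compound 3 (beyond the scatter), though not necessarily all the way back to compound 1. For compound 3 a value of -30% is estimated, in a range from -52% to -6%.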

Compound 3, a percentage reported as activity, at one concentration (the size of the read-out at that concentration, not a potency): -66%
Compound 3: the middle estimate sits 36 percentage points above what was measured; the measured number lies below the stated range.
By their numbers in this assay, from the lowest: compound 3; then compound 1; then compound 2.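

Under this assay, the 2,4-difluorophenyl group on the amine nitrogen in the ring gives a number 57.7 percentage points lower from compound 2 to compound 3 (beyond the scatter), so a carbon-only aromatic ring at this place need not carry the 4-chloro-3-(trifluoromethyl)phenyl pattern of compound 1 to give a number well below that of the pyridin-4-yl group in compound 2. The two halogen-bearing phenyl groups also differ from each other, with a number 19 percentage points lower from compound 1 to compound 3 (beyond the scatter), which shows that the choice and placing of the substituents on the phenyl ring still matter and leaves compound 3 with the strongest effect of the three at the one concentration tested; among these three compounds, none goes against the lower numbers of the halogen-bearing phenyl groups relative to pyridin-4-yl. Nothing available explains why these groups differ in this way.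

The compounds shown leave open how much of the change belongs to the halogens and how much to the carbon-only ring, a question that an unsubstituted phenyl group would help to settle. Going by these compounds, it also remains open how a 4-methoxyphenyl or a benzyl group would read on the same nitrogen, and how these single-concentration numbers would translate into potency.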